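Trifluoromethyl for Methoxy on a Shared Quinoline Core

The source may hold more compounds than are shown below. What is called first, only, known or untested is meant among the compounds shown, and "the series" means these compounds.

In a functional assay on the whole organism (strain Sprague-Dawley) for inhibition, with Rattus norvegicus as the target (a lower number here means that less compound is needed, a higher number that more compound is needed for the effect), compound 1 `COc1cccc2cc(C(=O)O)cnc12` gives 25 mg/kg, and compound 2 `COc1cccc2cc(-c3nn[nH]n3)cnc12` gives 2.5 mg/kg. Within the data shown here, the only step measured so far, a 10-fold lower number from compound 1 to compound 2 (1.00 log units; beyond the scatter), put 2H-tetrazol-5-yl in place of carboxy, and compound 2 stands lowest of the two numbers. Compound 3 `FC(F)(F)c1cccc2cc(-c3nn[nH]n3)cnc12` keeps that 2H-tetrazol-5-yl and differs from compound 2 only in trifluoromethyl in place of methoxy on an aromatic carbon. No measured step touches the methoxy or the trifluoromethyl, so this change has no precedent among these compounds. The step is therefore expected to be none beyond the scatter, no change at the digits printed from compound 2 to compound 3 (within the scatter). Compound 3 is expected to give about 2.5 mg/kg, between 0.8 mg/kg and 8 mg/kg.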

Compound 3, minimum effective dose: < 25 mg/kg
Compound 3 gave a limit, no number; the forecaster's own chance of this, stated with the estimate: 10%; the middle value lies beyond the limit too.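

In this assay compound 3 gives only a limit, < 25 mg/kg, and not a number, so its step from compound 2 cannot be read. The compounds shown leave open how trifluoromethyl in place of methoxy changes the dose needed.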